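A Bromo Swap on a Benzamide at the Limit

The source may hold more compounds than are shown below. What is called first, only, known or untested is meant among the compounds shown, and "the series" means these compounds.

compound 1 `Nc1cc(-c2ccccc2)ccc1NC(=O)c1ccc(CNc2nccc(-c3cccnc3)n2)cc1`: > 20000 nM
compound 2 `Nc1ccccc1NC(=O)c1ccc(CSC2=N[C@@H](Cc3ccccc3)CS2)cc1`: > 20000 nM
compound 3 `Nc1ccccc1NC(=O)c1ccc(CNC2=NC[C@H](c3ccccc3)S2)cc1`: "not determined" (no result reported)

Three compounds were tested in an assay on isolated protein for inhibition of protein deacetylase HDAC6 (Homo sapiens), read by fluorescence, with stated times of 3 h and 60 min; on this read-out higher numbers stand for weaker inhibition and lower numbers for stronger inhibition. For compound 1 the reported value > 20000 nM is a limit of the assay, not a number. Compound 2 likewise gives only a limit, > 20000 nM. For compound 3 no result was reported, "not determined" (no result reported). Two of the three values sit at the limit (the limit of > 20000 nM in this assay, at which 2 of the 3 values shown sit), so compound 1 stands where most of the set stands, with no number to rank it. The unmeasured compound 4 `Nc1cc(Br)ccc1NC(=O)c1ccc(CNc2nccc(-c3cccnc3)n2)cc1` differs from compound 1 by bromo in place of phenyl on an aromatic carbon. Going by the values given here, no step between measured compounds exists to gauge this change. The expected step is a number no higher from compound 1 to compound 4 (the limit leaves the size open), none beyond the scatter. The estimate for compound 4 is 20000 nM, between 8000 nM and 60000 nM.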

Compound 4, half-maximal inhibitory concentration: > 20000 nM
Compound 4 gave a limit, no number (the forecaster's own chance of this, stated with the estimate: 80%); the middle value lies on the limit itself.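

Compound 1 and compound 4 both give only a limit, not a number, so no step can be read for bromo in place of phenyl: the limit of > 20000 nM in this assay, at which 3 of the 4 values shown sit.

The compounds shown leave open how these two groups compare in strength of inhibition.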